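Swapping the Side Chain of Compound 2 for Piperazine

The source may hold more compounds than are shown below. What is called first, only, known or untested is meant among the compounds shown, and "the series" means these compounds.

In a physicochemical assay for solubility, at pH 7.4 (on this read-out higher numbers stand for higher solubility and lower numbers for lower solubility), compound 2 `CCCCNc1nc(N)c2[nH]c(=O)n(Cc3ccc(OCCCN(C)C)nc3)c2n1` gives 288000 ug/mL and compound 3 `CCCCNc1nc(N)c2[nH]c(=O)n(Cc3ccc(OCCCCN(C)C)nc3)c2n1` gives 350000 ug/mL, so these two numbers lie within the scatter of each other. Compound 1 `CCCCNc1nc(N)c2nc(O)n(Cc3ccc(OC)nc3)c2n1` is reported in this assay only as a limit, < 1000 ug/mL. Going by the values given here, compound 2 therefore stands alongside compound 3, the only other compound with a number.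

The next compound to be measured is compound 4 `CCCCNc1nc(N)c2[nH]c(=O)n(Cc3ccc(N4CCNCC4)nc3)c2n1`. It carries piperazin-1-yl in place of 3-(dimethylamino)propoxy on an aromatic carbon. This aromatic carbon belongs to a six-membered aromatic ring with 1 nitrogen and sits next to the ring nitrogen.

Among the compounds with values here, only one measured step bears on this change: a 1.2-fold higher number from compound 2 to compound 3 (0.08 log units; within the scatter). That step alters the chain alone and lies within the scatter. Within the data shown here, no measured step replaces the whole group, so it offers only weak guidance, and the expectation rests on compound 3 staying close to compound 2 in that step.

No change beyond the scatter is therefore expected, and the estimated step is a 1.4-fold lower number from compound 2 to compound 4 (0.16 log units; within the scatter). In this assay the estimated value for compound 4 is 200000 ug/mL, with an expected range from 40000 ug/mL to 500000 ug/mL.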

Compound 4, solubility: 63000 ug/mL
The estimate for compound 4 lay 3.2-fold (0.50 log units) above the measured number; low and high end bracket the measured number.
By their numbers in this assay, from the lowest: compound 4; then compounds 2 and 3 (each within the scatter of the next). At a limit, below all of these: compound 1.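

Going by these compounds alone, until this result, the only change at this position was in chain length, and that step stayed within the scatter: a 1.2-fold higher number from compound 2 to compound 3 (0.08 log units; within the scatter). In this assay, replacing the whole side chain on this aromatic carbon, next to the ring nitrogen, does move the number beyond the scatter: piperazin-1-yl in place of 3-(dimethylamino)propoxy gives a 4.6-fold lower number from compound 2 to compound 4 (0.66 log units; beyond the scatter), and piperazin-1-yl in place of 4-(dimethylamino)butoxy gives a 5.6-fold lower number from compound 3 to compound 4 (0.74 log units; beyond the scatter). The read-out at this position therefore responds to the kind of group there and not only to the length of the chain, though both steps are modest, and compound 1 remains a limit and not a number: the limit of < 1000 ug/mL in this assay, at which 1 of the 4 values shown sits.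

The change removes the open chain and its oxygen and brings in the ring in a single step, so the compounds shown cannot tell which of these goes with the lower number. A dimethylamino group set directly on this aromatic carbon, or a piperazine ring carried at the end of a propoxy chain, would pull those two parts of the change apart.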